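A few compounds are considered here, and "the series" means these few. Any claim that something is new, unique, unknown or untested is made for them only; others in the source may bear on it.

Measured in a functional assay on HT-29 cells (Homo sapiens) for cytotoxicity, read by MTT assay, with a stated time of 72 h; on this read-out lower numbers stand for stronger inhibition and higher numbers for weaker inhibition:
Compound 1 `COc1cc2c(Oc3ccc(NC(=O)c4nnn(-c5ccccc5C)c4C)cc3F)ccnc2cc1OCCCN1CCCCC1` gives 450 nM.
Compound 2 `COc1cc2c(Oc3ccc(NC(=O)c4nnn(-c5ccccc5)c4C)cc3F)ccnc2cc1OCCCN1CCCCC1` gives 120 nM.
Compound 3 `COc1cc2c(Oc3ccc(NC(=O)c4nnn(-c5ccccc5C)c4C)cc3F)ccnc2cc1OCCCN1CCC(C)CC1` gives 520 nM.

Compound 4 `COc1cc2c(Oc3ccc(NC(=O)c4nnn(-c5ccccc5)c4C)cc3F)ccnc2cc1OCCCN1CCC(C)CC1` has not been measured. It differs from compound 3 by one change, (hydrogen in place of methyl on an aromatic carbon). The same change, made on the other core, is hydrogen in place of methyl on an aromatic carbon, and there it gave a 3.8-fold lower number from compound 1 to compound 2 (0.57 log units; beyond the scatter). The two cores differ only in methyl in place of hydrogen on a saturated ring carbon, and that difference gave a 1.2-fold higher number from compound 1 to compound 3 (0.06 log units; within the scatter), so the two cores behave alike in this assay. Since the change is the same and the two starting points are within the scatter of each other, the step from compound 3 to compound 4 is expected to be about as large as the earlier one: a 3.7-fold lower number from compound 3 to compound 4 (0.57 log units; beyond the scatter). Compound 4 is therefore estimated at 140 nM, with a likely range from 60 nM to 330 nM.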

Compound 4, half-maximal inhibitory concentration: 140 nM
Beside the measured number, compound 4's estimate shows no gap at the digits printed, within the range that was stated.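

Going from 2-methylphenyl to phenyl gives a 3.7-fold lower number from compound 3 to compound 4 (0.57 log units; beyond the scatter) in this assay, and this step has the same size on both cores: the same change on two cores in this assay, a 3.8-fold lower number (0.57 log units; beyond the scatter) from compound 1 to compound 2 and a 3.7-fold lower number (0.57 log units; beyond the scatter) from compound 3 to compound 4, 1.0-fold (0.00 log units) apart, within the scatter of two such steps The methyl on the saturated ring carbon is a second change that stays within the scatter, with a 1.2-fold higher number from compound 2 to compound 4 (0.07 log units; within the scatter), and it behaves the same way on both cores: the same change on two cores in this assay, a 1.2-fold higher number (0.06 log units; within the scatter) from compound 1 to compound 3 and a 1.2-fold higher number (0.07 log units; within the scatter) from compound 2 to compound 4, 1.0-fold (0.00 log units) apart, within the scatter of two such steps Across these four compounds the two changes therefore act independently of each other, but this is one cell assay and one small set, so it neither explains the effect nor shows that it carries over to more distant cores.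

Still open, as far as these compounds go, is how a chlorine atom or a methoxy group in place of the aromatic methyl would behave. Also open, from the compounds shown here alone, is whether an ethyl group in place of the methyl on the saturated ring would leave the step unchanged.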